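Trifluoromethyl on compound 1: working notes

The compounds below may be only part of what the source reports. "The series", "measured", "known", "first", "only" and "open" are said of these compounds alone.

Measured so far in a functional assay on MCF7 cells (Homo sapiens) for inhibition, read by sulforhodamine B assay; on this read-out lower numbers stand for stronger inhibition of growth and higher numbers for weaker inhibition of growth
- compound 1 `c1ccc(-c2ccc(-c3ccc(-c4nc5ccccc5[nH]4)cc3)cc2)cc1` gives 39200 nM
- compound 2 `COc1ccc(-c2ccc(-c3ccc(-c4nc5cc(C)ccc5[nH]4)cc3)cc2)cc1OC` gives 190 nM

Compound 1 holds the higher of the two numbers, and the gap down to compound 2 lies beyond the scatter. The two compounds differ in more than one place, so that gap cannot be assigned to any single change. For the measured compounds named here, no measured pair differing in one place is available.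

The next compound is compound 3 `FC(F)(F)c1ccc(-c2ccc(-c3ccc(-c4nc5ccccc5[nH]4)cc3)cc2)cc1`, which carries trifluoromethyl in place of hydrogen on an aromatic carbon.

Going by the values given here, the only guide is the lower number of compound 2 (190 nM), which gives weak support for a fall. In this assay a modest fall is expected (a 3.3-fold lower number from compound 1 to compound 3 (0.51 log units; beyond the scatter)), beyond the scatter but well short of that gap. For compound 3 the estimated value is 12000 nM (range 3000 nM to 45000 nM).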

Compound 3, concentration for 50% growth inhibition: 41400 nM
Beside the measured number, compound 3's estimate is 3.5-fold (0.54 log units) below it; the measured number falls inside the stated range.
By their numbers in this assay, from the lowest: compound 2; then compounds 1 and 3 (each within the scatter of the next).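

In this assay, for the compounds shown here, trifluoromethyl in place of hydrogen on an aromatic carbon, para to a large group, gives a 1.1-fold higher number from compound 1 to compound 3 (0.02 log units; within the scatter), the first one-place step. At this position, then, the phenyl to 4-(trifluoromethyl)phenyl change separates compound 1 and compound 3 by no more than the scatter, and both numbers stand in the same range. Nothing available on the compounds explains this result.

Going by these compounds alone, the lower number of compound 2 remains unassigned, since it differs from compound 1 in more than one place, and the methyl and the methoxy groups it carries have no one-place steps of their own. On these data alone, whether another group at this position, such as an amine or a carboxylic acid, would move the number also stays open.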